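The source may report more compounds than this note shows. Statements on the series, on what has been measured and on what is new or still open speak of the compounds shown alone.

Measured in a functional assay on the whole organism (artery, strain albino) with Rattus norvegicus as the target, with a stated time of 900 min, at a dose of 10 mg/kg by the oral route; a lower number here means less inhibition, a higher number more inhibition at the dose given (going by the name of the read-out):

compound 1, `CC1=C(C(=O)Nc2ccc(Br)cc2)C(c2ccc(Cl)cc2Cl)N=C(SCc2cccc(Cl)c2)N1`: 7.2%
compound 2, `CC1=C(C(=O)Nc2ccc(Br)cc2)C(c2ccc(Cl)cc2Cl)N=C(SCc2ccc(Cl)cc2)N1`: 22.1%
compound 3, `COc1ccc(C2N=C(SCc3cccc(Cl)c3)NC(C)=C2C(=O)Nc2ccc(Br)cc2)cc1`: 22.6%

For the measured compounds named here, the one structural change for which a measured pair exists is 4-chlorophenyl in place of 3-chlorophenyl on a saturated chain carbon bound to a sulfur. It gives a number 14.9 percentage points higher from compound 1 to compound 2 (beyond the scatter). Compound 1 thus sits lowest of the three measured numbers, while compound 2 and compound 3 give numbers that lie within the scatter of each other, so no order between those two is claimed.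

Compound 3 differs from compound 1 in its core: 4-methoxyphenyl in place of 2,4-dichlorophenyl on a saturated ring carbon. That core difference carries a number 15.4 percentage points higher from compound 1 to compound 3 (beyond the scatter).

Compound 4, `COc1ccc(C2N=C(SCc3ccc(Cl)cc3)NC(C)=C2C(=O)Nc2ccc(Br)cc2)cc1`, is not yet measured. It is related to compound 3 by 4-chlorophenyl in place of 3-chlorophenyl on a saturated chain carbon bound to a sulfur. The place of this change is the same, word for word, as in the pair of compound 1 and compound 2, so the change from compound 3 to compound 4 is the same change, now made on the other core.

Going by the values given here, with only one measured instance of the change, the expectation for compound 4 rests on that single step: the step of a number 14.9 percentage points higher from compound 1 to compound 2 (beyond the scatter) on the core of compound 1 is taken as the guide, so a step of about a number 12.4 percentage points higher from compound 3 to compound 4 (beyond the scatter) is expected from compound 3 to compound 4 in this assay, with a wide band because a step seen once may not repeat in size on a different core. Compound 4 is estimated to give 35% in this assay, with a likely range from 18% to 52%.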

Compound 4, a percentage reported as inhibition, in the whole organism at one dose (the size of the read-out at that dose, not a potency): 20%
For compound 4 the middle estimate is 15 percentage points above the measured one, and the stated range covers the measured number.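

With 4-chlorophenyl in place of 3-chlorophenyl on a saturated chain carbon bound to a sulfur, the second core gives a number 2.6 percentage points lower from compound 3 to compound 4 (within the scatter) in this assay, so the rise seen on the core of compound 1 does not carry over in size: the same change on two cores in this assay, a number 14.9 percentage points higher (beyond the scatter) from compound 1 to compound 2 and a number 2.6 percentage points lower (within the scatter) from compound 3 to compound 4, 17.5 percentage points apart, beyond the scatter of two such steps

Read the other way, 4-methoxyphenyl in place of 2,4-dichlorophenyl on a saturated ring carbon gives a number 2.1 percentage points lower from compound 2 to compound 4 (within the scatter), so that change also fails to keep its size once the chlorobenzyl group differs: the same change on two cores in this assay, a number 15.4 percentage points higher (beyond the scatter) from compound 1 to compound 3 and a number 2.1 percentage points lower (within the scatter) from compound 2 to compound 4, 17.5 percentage points apart, beyond the scatter of two such steps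

Both steps beyond the scatter start from compound 1, so these four compounds cannot separate a true dependence on the core from a single low reading for compound 1, and they give no rule for any core beyond the two shown.

From the compounds shown here alone, all four compounds carry a chlorobenzyl group on the sulfur and share the same amide, so it remains open how an amine or a carboxylic acid on that benzyl ring, or a longer chain between the sulfur and the ring, would behave in this assay. Also open, going by these compounds, is whether the two changes would keep or lose their size at another dose or time.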